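The source may hold more compounds than are shown below. What is called first, only, known or untested is meant among the compounds shown, and "the series" means these compounds.

Working notes on the series in an ADME assay on WI-38 cells (Homo sapiens) for inhibition, read by MTT assay, with a stated time of 72 h; on this read-out higher numbers stand for weaker inhibition and lower numbers for stronger inhibition.

Going by the values given here, compound 1 `Cc1ccc(C(=O)OC2(C(=O)Nc3ccc([N+](=O)[O-])cc3)CCCCC2)cc1` gives 32 nM in this assay, the lowest of the three numbers measured so far. Compound 3 `CCC(=O)OC1(C(=O)Nc2ccc([N+](=O)[O-])cc2)CCCCC1` gives 44.6 nM, and the step of a 1.4-fold higher number from compound 1 to compound 3 (0.14 log units; within the scatter) lies within the scatter. Compound 2 `O=C(OC1(C(=O)Nc2ccc([N+](=O)[O-])cc2)CCCCC1)c1ccc([N+](=O)[O-])cc1` gives 761 nM, reached by the step of a 24-fold higher number from compound 1 to compound 2 (1.38 log units; beyond the scatter); from there, a 17-fold lower number from compound 2 to compound 3 (1.23 log units; beyond the scatter) returns to the lower range.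

Compound 4 `CC(=O)Oc1ccccc1C(=O)OC1(C(=O)Nc2ccc([N+](=O)[O-])cc2)CCCCC1` differs from compound 1 by 2-acetoxyphenyl in place of 4-methylphenyl on a carbonyl carbon. The step from compound 1 to compound 2 shows that a change on the ester aryl can cost a large amount; the step from compound 1 to compound 3 shows that the ester part itself can vary without effect beyond the scatter. The new group brings two hydrogen-bond acceptors, as the nitro of compound 2 does, so a moderate rise in the number is expected for compound 4, smaller than a 24-fold higher number from compound 1 to compound 2 (1.38 log units; beyond the scatter): the expected step is a 2.8-fold higher number from compound 1 to compound 4 (0.45 log units; beyond the scatter), giving an estimate of 90 nM with a range of 30 nM to 300 nM.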

Compound 4, half-maximal inhibitory concentration: 48.4 nM
The estimate for compound 4 lay 1.9-fold (0.27 log units) above the measured number; the range from low to high includes it.
By their numbers in this assay, from the lowest: compounds 1, 3 and 4 (each within the scatter of the next); then compound 2.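

On the carbonyl carbon, 2-acetoxyphenyl reads the same as 4-methylphenyl (a 1.5-fold higher number from compound 1 to compound 4 (0.18 log units; within the scatter)) and ethyl (a 1.1-fold higher number from compound 3 to compound 4 (0.04 log units; within the scatter)), so its two hydrogen-bond acceptors do not by themselves bring the rise seen with 4-nitrophenyl. Compound 2 stays apart from compound 4 (a 16-fold lower number from compound 2 to compound 4 (1.20 log units; beyond the scatter)), leaving it as the only outlier among the four compounds. No measured evidence bears on this difference.

From the compounds shown here alone, whether the large step belongs to the nitro group specifically remains open. A 4-aminophenyl or 4-carboxyphenyl group on the same carbonyl carbon would test this, and a longer chain in place of ethyl would extend the comparison.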